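Swapping a Benzyl for a Benzoyl on the Amine

The compounds below may be only part of what the source reports. "The series", "measured", "known", "first", "only" and "open" are said of these compounds alone.

Compound 2 `C[C@@H](NC(=O)[C@H](CCCNC(=N)N)NC(=O)c1ccc(CN(Cc2ccc(F)cc2)Cc2cccnc2)cc1)c1cccc2ccccc12` gives 37000 nM in an ADME assay on MT4 cells (Homo sapiens) for cytotoxicity (a lower number here means that less compound is tolerated, a higher number that more compound is tolerated), the second highest of three numbers; compound 3 `C[C@@H](NC(=O)[C@H](CCCNC(=N)N)NC(=O)c1ccc(CN(Cc2ccncc2)Cc2ccc(F)cc2)cc1)c1cccc2ccccc12` gives 39000 nM and compound 1 `C[C@@H](NC(=O)[C@H](CCCNC(=N)N)NC(=O)c1ccc(CN(Cc2ccc(F)cc2)Cc2ccccn2)cc1)c1cccc2ccccc12` gives 35000 nM, and both lie within the scatter of compound 2. The measured steps change only the pyridyl: a 1.1-fold higher number from compound 1 to compound 2 (0.02 log units; within the scatter), a 1.1-fold higher number from compound 1 to compound 3 (0.05 log units; within the scatter) and a 1.1-fold higher number from compound 2 to compound 3 (0.02 log units; within the scatter), all within the scatter. Compound 4 `C[C@@H](NC(=O)[C@H](CCCNC(=N)N)NC(=O)c1ccc(CN(Cc2cccnc2)C(=O)c2ccc(F)cc2)cc1)c1cccc2ccccc12` differs from compound 2 by (4-fluorophenyl)carbonyl in place of 4-fluorobenzyl on an amine nitrogen. For the measured compounds named here, no measured step covers this change; the pyridyl steps bear on it only by showing that edits on the same amine nitrogen left this assay unmoved. The expected step is therefore no change at the digits printed from compound 2 to compound 4 (within the scatter), none beyond the scatter. Compound 4 is estimated at 37000 nM, within a range from 15000 nM to 90000 nM.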

Compound 4, half-maximal cytotoxic concentration: 45000 nM
The estimate for compound 4 lay 1.2-fold (0.09 log units) below the measured number; the measured number falls inside the stated range.
By their numbers in this assay, from the lowest: compounds 1, 2, 3 and 4 (each within the scatter of the next).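

Replacing 4-fluorobenzyl with (4-fluorophenyl)carbonyl on the amine nitrogen gives, in this assay, a 1.2-fold higher number from compound 2 to compound 4 (0.09 log units; within the scatter). The pyridyl steps varied only the ring, whereas this one places a carbonyl directly on that nitrogen and adds a hydrogen-bond acceptor, and it still stays within the scatter. No supporting measurement bears on this result.

The compounds shown leave open whether a carboxylic acid or a primary amine on the 4-fluorophenyl ring would also stay within the scatter. Going by these compounds, a sulfonyl in place of the carbonyl is equally open.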